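The source may report more compounds than this note shows. Statements on the series, on what has been measured and on what is new or still open speak of the compounds shown alone.

In an ADME assay on a cell-free system (plasma, Homo sapiens) for metabolic stability, tested at 1 uM (on this read-out higher numbers stand for a longer-lived compound and lower numbers for a shorter-lived compound), compound 1 (`C=CC(=O)N[C@@H]1CCCN(S(=O)(=O)c2ccc(NC(=O)OCc3ccccc3)cc2)C1`) stands at > 6 h as a limit of the assay. Compound 2 (`C=CC(=O)NC1CCN(S(=O)(=O)c2ccc(C(=O)NCCCc3ccccc3)cc2)CC1`) stands at > 6 h as a limit too, so its exact half-life is not known. Compound 3 (`C=CC(=O)NC1CCN(S(=O)(=O)c2ccc(C(=O)N(C)Cc3ccccc3)cc2)CC1`) has benzyl(methyl)amino in place of (3-phenylpropyl)amino on a carbonyl carbon. Within the data shown here, no measured step tests this change. In this assay no shift in either direction beyond the scatter is expected, because the limit of > 6 h in this assay, at which 2 of the 2 values shown sit, is all the series shows so far. The expected step is a step that the limit leaves unreadable from compound 2 to compound 3 as a rough estimate. Compound 3 is estimated at 8 h with 4 h to 16 h as the expected range.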

Compound 3, half-life: > 6 h
Compound 3 gave a limit, no number (the forecaster's own chance of this, stated with the estimate: 80%); the middle value is on the limit's open side.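

The step from compound 2 to compound 3 cannot be read, as both values are limits and not numbers. From the compounds shown here alone, the actual half-lives of compound 1, compound 2 and compound 3 stay open, as does any effect of benzyl(methyl)amino replacing (3-phenylpropyl)amino.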